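The compounds below may be only part of what the source reports. "The series", "measured", "known", "first", "only" and "open" are said of these compounds alone.

Of the compounds shown here, three of this set have been tested in an ADME assay on microsomes from liver (Homo sapiens) for metabolic stability, read by LC-MS, with NADPH named in the record, with a stated time of 60 min, tested at 1 uM, in the absence of a further agent; on this read-out lower numbers stand for a less stable compound and higher numbers for a more stable compound. Compound 1 `COc1ccc(-c2scc3c(N4CC[C@@H](NC(C)=O)C4)nc(C)nc23)cc1OC` gives in this assay a value that is a limit of the assay, > 95%. Compound 2 `CC(=O)N[C@@H]1CCN(c2cc(C)nn3c(-c4nccs4)c(C)nc23)C1` likewise returns in this assay only a limit, > 95%. Compound 3 `CCCCCC(=O)N[C@@H]1CCN(c2cc(C)nn3c(-c4ccc(OC)c(OC)c4)c(C)nc23)C1`, which carries the pentylcarbonyl group on the amine nitrogen, also reaches in this assay nothing more than a limit, > 95%. Among the measured compounds shown here, because of the limit of > 95% in this assay, at which 3 of the 3 values shown sit, compound 3 cannot be set above or below its two companions: all three stand at the same limit, and no step between any two measured compounds can be counted from these numbers.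

The next compound, compound 4 `COc1ccc(-c2c(C)nc3c(N4CC[C@@H](NS(=O)(=O)c5ccccc5)C4)cc(C)nn23)cc1OC`, is built from compound 3 by a single change on the amine nitrogen whose other neighbours are a saturated ring carbon: phenylsulfonyl in place of pentylcarbonyl on an amine nitrogen. For the measured compounds named here, no measured pair in the set differs in one place, so there is no measured step to lean on.

Because compound 3 already sits at the limit > 95% and every tested member of the set does the same, compound 4 is expected to show a step of a number at least 2 percentage points lower from compound 3 to compound 4 (that floor lies within the scatter) that does not exceed the scatter, in no clear direction. Compound 4 is accordingly estimated at 93%, within a range from 80% to 100%.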

Compound 4, percent of the compound remaining: > 95%
Compound 4: only a limit was reported (the forecaster's own chance of this, stated with the estimate: 60%); middle value at least 2 percentage points away from the limit.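

Among the compounds shown here, no step from compound 3 to compound 4 can be read, because the two compounds stand at one shared limit: the limit of > 95% in this assay, at which 4 of the 4 values shown sit.

The compounds shown leave open whether phenylsulfonyl in place of pentylcarbonyl on an amine nitrogen changes the percent of compound remaining in this assay at all, and which change to this set would bring a value off the limit.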